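The compounds below may be only part of what the source reports. "The series", "measured", "known", "first", "only" and "open" are said of these compounds alone.

Of the compounds shown here, three have been measured in a functional assay on CHO cells for agonist activity at metabotropic glutamate receptor 2 (Homo sapiens), read by GTPgammaS binding; on this read-out higher numbers stand for an effect only at larger amounts of compound and lower numbers for an effect already at smaller amounts. Compound 1 `N#Cc1c(-c2ccc(OC3CCOCC3)c(Cl)c2)ccn2c(CC(F)(F)F)cnc12` gives 617 nM, the highest of the three numbers. Compound 3 `N#Cc1c(-c2cc(Cl)c3[nH]ccc3c2)ccn2c(CC(F)(F)F)cnc12` gives 320 nM, which lies within the usual scatter of compound 1. Going by the values given here, compound 2 `FC(F)(F)Cc1cnc2c(Cl)c(-c3cc(Cl)c4[nH]ccc4c3)ccn12` gives 85 nM, the only value separated from compound 1 beyond the scatter.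

Compound 4 `N#Cc1c(-c2ccc(NC3CCOCC3)c(Cl)c2)ccn2c(CC(F)(F)F)cnc12` is not yet measured; it differs from compound 1 in one place: (oxan-4-yl)amino in place of (oxan-4-yl)oxy on an aromatic carbon. Among the compounds with values here, the single measured step, a 3.8-fold higher number from compound 2 to compound 3 (0.58 log units; beyond the scatter), concerns cyano in place of chloro on the shared core and does not touch the (oxan-4-yl)oxy group; no measured pair shows (oxan-4-yl)amino in place of (oxan-4-yl)oxy. The expectation for this assay therefore rests on compound 1 alone, and a step not beyond the scatter is expected, that is a 1.2-fold lower number from compound 1 to compound 4 (0.09 log units; within the scatter). Compound 4 is estimated at 500 nM, with a range from 180 nM to 1500 nM.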

Compound 4, half-maximal effective concentration: 710 nM
For compound 4 the middle estimate is 1.4-fold (0.15 log units) below the measured one; low and high end bracket the measured number.
By their numbers in this assay, from the lowest: compound 2; then compounds 3, 1 and 4 (each within the scatter of the next, the first and the last beyond it).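

In this assay, going by these compounds alone, the exchange of (oxan-4-yl)oxy for (oxan-4-yl)amino gives a 1.2-fold higher number from compound 1 to compound 4 (0.06 log units; within the scatter), the first measured change at this place, on an aromatic carbon ortho to a chloro group and para to a large group. The entering group brings a hydrogen-bond donor that the leaving group lacks, while the heavy-atom count and the six-membered non-aromatic ring stay the same, and this read-out does not separate the two groups on this core. No supporting data bear on the reason for this result.

Open, from the compounds shown here alone, is whether the same exchange would also stay within the scatter on the chloro-bearing core of compound 2. Also open, going by these compounds, is how a tertiary N-methyl amine, a morpholine or a carboxylic acid would read at this place.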